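Swapping an oxazole ethyl for bromo on a potent antagonist

The source may report more compounds than this note shows. Statements on the series, on what has been measured and on what is new or still open speak of the compounds shown alone.

Among the compounds with values here, compound 2 `CCc1nc(Nc2cccc3c2CC(O)CC3)oc1-c1ccc(C(F)(F)F)cc1` gives 2.1 nM in an in vitro functional assay on cells for antagonist activity at transient receptor potential cation channel subfamily V member 1 (Homo sapiens), read by FLIPR and calcium flux (a higher number here means a weaker inhibitor, a lower number a stronger inhibitor), the lower of the two numbers known so far. Compound 1 `Cc1ccccc1-c1cnc(Nc2cccc3c2CC(O)CC3)o1` gives 416 nM in this assay, a gap from compound 2 that lies well beyond the scatter. Compound 3 `OC1CCc2cccc(Nc3nc(Br)c(-c4ccc(C(F)(F)F)cc4)o3)c2C1` is the next candidate; it differs from compound 2 by bromo in place of ethyl on an aromatic carbon. Within the data shown here, with no measured pair showing this change, the step is expected to be small, at most a slight loss. Compound 3 is estimated at 5 nM, with a range from 1.5 nM to 20 nM, which would mean a step of a 2.4-fold higher number from compound 2 to compound 3 (0.38 log units; beyond the scatter) from the known value.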

Compound 3, half-maximal inhibitory concentration: 9 nM
Estimate against measurement, compound 3: 1.8-fold (0.26 log units) below; the measured number falls inside the stated range.
By their numbers in this assay, from the lowest: compound 2; then compound 3; then compound 1.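

In this assay, within the data shown here, the first single-place reading at this position is a 4.3-fold higher number from compound 2 to compound 3 (0.63 log units; beyond the scatter), a modest step beyond the scatter when bromo replaces ethyl on the aromatic carbon next to the ring nitrogen. Ethyl is therefore not required for a low number here, as compound 3 still gives 9 nM, though bromo does not match it. Nothing available explains the rise.

As far as these compounds go, how chloro, a nitrile or a longer chain such as propyl would compare on this carbon stays open, as does whether this step holds with other groups on the neighbouring ring atom.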